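The source may report more compounds than this note shows. Statements on the series, on what has been measured and on what is new or still open speak of the compounds shown alone.

Working notes on the series. Among the compounds with values here, compound 1 `COc1cc(C)cc(-c2c(-c3ccnc(-c4ccc(C(C)=O)cc4)c3)cnn2CC#N)c1` stands highest of the three numbers so far in a functional assay on MDA-MB-231 cells (Homo sapiens) for cytotoxicity, read by sulforhodamine B assay, with a stated time of 48 h, tested at 100 nM (on this read-out higher numbers stand for a weaker effect at the one concentration tested and lower numbers for a stronger effect), where compound 1 gives 86%. Compound 2 `Cc1cc(O)cc(-c2nn(CC#N)cc2-c2ccnc(-c3ccc(Oc4ccccc4)cc3)c2)c1` sits within the scatter of it; in this assay compound 2 gives 85%. Compound 3 `COc1cc(C)cc(-c2nn(CC#N)cc2-c2ccnc(-c3ccc(N(C)C)cc3)c2)c1` lies well apart, beyond the scatter; in this assay compound 3 gives 52%. Within the data shown here, no single-change step between measured compounds is available.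

The next compound, compound 4 `COc1cc(C)cc(-c2c(-c3ccnc(-c4ccc(N(C)C)cc4)c3)cnn2CC#N)c1`, differs from compound 1 by one change: dimethylamino in place of acetyl on an aromatic carbon. Compound 3 carries a dimethylamino group as well, and its value of 52% suggests a downward step in this assay. The step from compound 1 to compound 4 is expected to read a number 26 percentage points lower from compound 1 to compound 4 (beyond the scatter), beyond the scatter. For compound 4 the estimate is 60%, within 40% to 80%.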

Compound 4, a percentage reported as activity, at one concentration (the size of the read-out at that concentration, not a potency): -5%
Compound 4: middle estimate off by 65 percentage points, on the high side, outside the stated range (below it).
By their numbers in this assay, from the lowest: compound 4; then compound 3; then compounds 2 and 1 (each within the scatter of the next).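

In this assay, within the data shown here, the 4-acetylphenyl to 4-(dimethylamino)phenyl change gives the first single-change step, a number 91 percentage points lower from compound 1 to compound 4 (beyond the scatter), so the read-out at the one concentration tested is highly sensitive to the group at this place on the core of compound 1. The two groups match in heavy-atom count and in hydrogen-bond donors and acceptors, so these counts do not separate compound 1 from compound 4. Nothing available explains the size of this step.

Going by these compounds, whether a primary amine, a methoxy group or a carboxylic acid at this place reads like dimethylamino or like acetyl remains open. A single concentration also leaves the effect of compound 4 at other concentrations open.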